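Replacing a hydroxy-bearing aryl group with 4-ethylphenyl

A few compounds are considered here, and "the series" means these few. Any claim that something is new, unique, unknown or untested is made for them only; others in the source may bear on it.

Measured so far in a functional assay on MDA-MB-468 cells (Homo sapiens) for inhibition, read by sulforhodamine B assay, with a stated time of 48 h; on this read-out lower numbers stand for stronger inhibition of growth and higher numbers for weaker inhibition of growth:
compound 1 `Cc1ccc(C2=NN(c3ccc(S(C)(=O)=O)cc3)C(=O)CC2)cc1` gives 4860 nM
compound 2 `Cc1cc(O)ccc1C1=NN(c2ccc(S(C)(=O)=O)cc2)C(=O)CC1` gives 44300 nM

Of these two compounds, compound 2 has the higher number, 44300 nM, and so the weaker inhibition of growth. The next compound, compound 3 `CCc1ccc(C2=NN(c3ccc(S(C)(=O)=O)cc3)C(=O)CC2)cc1`, has not been measured. Its change from compound 2 is 4-ethylphenyl in place of 4-hydroxy-2-methylphenyl on a carbon with a double bond to nitrogen, that is, 4-ethylphenyl in place of 4-hydroxy-2-methylphenyl. Among the compounds with values here, only one measured step bears on this: a 9.1-fold higher number from compound 1 to compound 2 (0.96 log units; beyond the scatter), a modest step beyond the scatter, made by bringing in 4-hydroxy-2-methylphenyl in place of 4-methylphenyl. Going by these compounds, compound 3 removes that same group, although ethyl in place of methyl remains untested. A step of similar size towards a lower number is therefore expected in this assay, landing near compound 1 at 4860 nM. The estimated step is an 8.9-fold lower number from compound 2 to compound 3 (0.95 log units; beyond the scatter). Compound 3 is expected at 5000 nM, with an estimated range from 1800 nM to 14000 nM.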

Compound 3, concentration for total growth inhibition: 31200 nM
The estimate for compound 3 lay 6.2-fold (0.80 log units) below the measured number, and the stated range ends below it.
By their numbers in this assay, from the lowest: compound 1; then compounds 3 and 2 (each within the scatter of the next).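

In this assay, the group on the carbon with a double bond to nitrogen tolerates even a small change poorly: methyl in place of hydrogen on the chain of the 4-methylphenyl group gives a 6.4-fold higher number from compound 1 to compound 3 (0.81 log units; beyond the scatter) and so takes compound 3 well away from compound 1. 4-Ethylphenyl in place of 4-hydroxy-2-methylphenyl gives a 1.4-fold lower number from compound 2 to compound 3 (0.15 log units; within the scatter) and so leaves compound 3 level with compound 2, which shows that a group without the hydroxy can still match the hydroxy-bearing one here. No measurement shown here explains either result.

Going by these compounds, it stays open whether a longer chain such as propyl would move the number further in the same direction. On these data alone, it is equally open how an amine or a methoxy group would behave in place of the ethyl group.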